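The source may report more compounds than this note shows. Statements on the series, on what has been measured and on what is new or still open speak of the compounds shown alone.

In an ADME assay on L6 cells (Rattus norvegicus) for cytotoxicity (on this read-out lower numbers stand for stronger inhibition and higher numbers for weaker inhibition), compound 1 (`O=C(NCCCCn1cnc([N+](=O)[O-])n1)c1ccc(C(F)(F)F)cc1`) gives 104000 nM and compound 2 (`O=[N+]([O-])c1ncn(CCNS(=O)(=O)c2cc(C(F)(F)F)cc(C(F)(F)F)c2)n1`) gives 111000 nM and so stands level with compound 1, within the scatter. Compound 3 (`O=[N+]([O-])c1ncn(CCCNS(=O)(=O)c2cc(C(F)(F)F)cc(C(F)(F)F)c2)n1`) awaits measurement. It departs from compound 2 by (3-nitro-1H-1,2,4-triazol-1-yl)methyl in place of 3-nitro-1H-1,2,4-triazol-1-yl on a saturated chain carbon, two bonds along the chain from a sulfonamide nitrogen. Among the compounds with values here, no measured step shows what such a change does, so no step beyond the scatter is expected in this assay, in either direction. The expected change is a 1.1-fold lower number from compound 2 to compound 3 (0.05 log units; within the scatter) and stays small. For compound 3 the estimated value is 100000 nM (expected range 55000 nM to 180000 nM).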

Compound 3, half-maximal inhibitory concentration: 109000 nM
The estimate for compound 3 lay 1.1-fold (0.04 log units) below the measured number, and the stated range covers the measured number.
By their numbers in this assay, from the lowest: compounds 1, 3 and 2 (each within the scatter of the next).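

In this assay, lengthening the chain, with (3-nitro-1H-1,2,4-triazol-1-yl)methyl in place of 3-nitro-1H-1,2,4-triazol-1-yl on a saturated chain carbon, two bonds along the chain from a sulfonamide nitrogen, gives a 1.0-fold lower number from compound 2 to compound 3 (0.01 log units; within the scatter) as the first read of this position. Within the data shown here, at this place, then, the one change tried leaves the read-out level. No measurement at hand gives a reason for this result. Still open, going by these compounds, is whether an amine or a carboxylic acid at this place, or a longer chain, would move the number beyond the scatter.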